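The compounds below may be only part of what the source reports. "The series", "measured", "known", "first", "only" and "open" are said of these compounds alone.

Compound 1 `O=C1Nc2ccc(S(=O)(=O)N3CCOCC3)cc2/C1=N/NC(=O)c1ccccc1`: 18100 nM
Compound 2 `O=C1Nc2ccc(S(=O)(=O)N3CCOCC3)cc2/C1=N/NS(=O)(=O)c1ccccc1`: 23900 nM
Compound 3 `O=C1Nc2ccc(S(=O)(=O)N3CCOCC3)cc2/C1=N/c1cccc(C(F)(F)F)c1`: 14300 nM

These three compounds share one core and were each tested in a functional assay on HepG2 cells (Homo sapiens) for cytotoxicity, read by sulforhodamine B assay, with a stated time of 24 h; on this read-out higher numbers stand for weaker inhibition and lower numbers for stronger inhibition. Compound 2 gives the highest of the three numbers, yet the gaps are small: a 1.3-fold higher number from compound 1 to compound 2 (0.12 log units; within the scatter) and a 1.7-fold lower number from compound 2 to compound 3 (0.22 log units; within the scatter) both lie within the scatter, so none of the three can be called more or less active than another.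

Compound 4 `CC(=O)c1cccc(/N=C2\C(=O)Nc3ccc(S(=O)(=O)N4CCOCC4)cc32)c1` has not yet been measured. It differs from compound 2 in one place: 3-acetylphenyl in place of (phenylsulfonyl)amino on a double-bonded nitrogen. The closest measured step is the one in which the same group leaves and a related phenyl enters, a 1.7-fold lower number from compound 2 to compound 3 (0.22 log units; within the scatter); a second comparison of a nitrogen-linked group against a phenyl ring, a 1.3-fold lower number from compound 1 to compound 3 (0.10 log units; within the scatter), was likewise within the scatter. On that basis the step from compound 2 to compound 4 is expected to stay within the scatter as well, a 1.6-fold lower number from compound 2 to compound 4 (0.20 log units; within the scatter).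

For compound 4 the expected value in this assay is 15000 nM, estimated to fall between 7000 nM and 32000 nM.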

Compound 4, half-maximal inhibitory concentration: 28600 nM
Compound 4: middle estimate off by 1.9-fold (0.28 log units), on the low side; low and high end bracket the measured number.
By their numbers in this assay, from the lowest: compounds 3, 1, 2 and 4 (each within the scatter of the next).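

Placing 3-acetylphenyl on the double-bonded nitrogen gives a 1.2-fold higher number from compound 2 to compound 4 (0.08 log units; within the scatter) in place of (phenylsulfonyl)amino and a 1.6-fold higher number from compound 1 to compound 4 (0.20 log units; within the scatter) in place of benzamido, so in this assay four different groups at this position have now produced no step beyond the scatter. The result also adds a change on an aromatic carbon, acetyl in place of trifluoromethyl, and a 2.0-fold higher number from compound 3 to compound 4 (0.30 log units; within the scatter) is the largest step in the set but still does not separate the two compounds. No measured evidence bears on why the numbers stay so close.

From the compounds shown here alone, it remains open whether an amine or a carboxylic acid on an aromatic carbon of this phenyl ring would move the number beyond the scatter. Going by these compounds, it is equally open whether a longer chain on the double-bonded nitrogen would do so.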